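This account rests on a few compounds, and the source may have more. Where it says the series, first, only, none or still open, it means among the compounds named here.

Of the compounds shown here, three that share one core have been tested in an assay on CHO cells for agonist activity at G protein-coupled receptor GPR35 (Rattus norvegicus), read by a beta-galactosidase reporter and beta-arrestin recruitment, with a stated time of 90 min; on this read-out higher numbers stand for an effect only at larger amounts of compound and lower numbers for an effect already at smaller amounts. Compound 1 `COc1ccc(C(=O)Nc2cc(Br)cc3c(=O)cc(C(=O)O)oc23)c(Cl)c1` gives 4170 nM in this assay, the highest of the three numbers. Compound 2 `Cc1cccc(C(=O)Nc2cc(Cl)cc3c(=O)cc(C(=O)O)oc23)c1` gives 2100 nM in this assay, a number that lies within the usual scatter of the number for compound 1, so the two cannot be told apart. Compound 3 `O=C(O)c1cc(=O)c2cccc(NC(=O)C3CCCCC3)c2o1` gives 1200 nM in this assay, a lower number than compound 1 shows, and the gap is beyond the scatter.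

Compound 4 `COc1ccccc1C(=O)Nc1cc(Br)cc2c(=O)cc(C(=O)O)oc12` has not yet been measured. It differs from compound 1 in one place: 2-methoxyphenyl in place of 2-chloro-4-methoxyphenyl on a carbonyl carbon. Among the measured compounds shown here, no pair of measured compounds differs in this way, so the size and direction of such a step cannot be read from the data. The expectation for compound 4 is a small step toward a higher number, no larger than the scatter itself, expected as a 1.4-fold higher number from compound 1 to compound 4 (0.16 log units; within the scatter). Compound 4 is therefore estimated to give 6000 nM in this assay, within a range from 2000 nM to 18000 nM.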

Compound 4, half-maximal effective concentration: 1100 nM
Compound 4: the middle estimate sits 5.5-fold (0.74 log units) above what was measured; the whole stated range lies above it.
By their numbers in this assay, from the lowest: compounds 4, 3, 2 and 1 (each within the scatter of the next, the first and the last beyond it).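

Replacing 2-chloro-4-methoxyphenyl with 2-methoxyphenyl on the carbonyl carbon gives a 3.8-fold lower number from compound 1 to compound 4 (0.58 log units; beyond the scatter) in this assay, beyond the usual scatter. Among the compounds shown here, this is the first change in a single place that can be read here. The three earlier compounds differ from one another in more than one place. This step shows that the group on this carbonyl carbon can alter the number. With bromine and the rest of the core of compound 1 kept, the group without chlorine gives an effect at smaller amounts, although no measurement at hand explains this step.

The compounds shown do not separate the loss of the chlorine from the change in the methoxy-bearing group. They also leave open how a plain phenyl or a 2-hydroxyphenyl on this same carbonyl carbon would read.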